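A Halogen Swap at the Aryl End of a Shared Core

The compounds below may be only part of what the source reports. "The series", "measured", "known", "first", "only" and "open" are said of these compounds alone.

Compound 1 `CC1=C(/C=C/C(=O)/C=C/c2ccc(C)cc2)C(C)(C)CCC1`: 21500 nM
Compound 2 `CC1=C(/C=C/C(=O)/C=C/c2ccc([N+](=O)[O-])cc2)C(C)(C)CCC1`: 1900 nM
Compound 3 `CC1=C(/C=C/C(=O)/C=C/c2ccccc2Cl)C(C)(C)CCC1`: 11300 nM

In a functional assay on PC-3 cells (Homo sapiens) for cytotoxicity, read by sulforhodamine B assay, with a stated time of 48 h (on this read-out higher numbers stand for weaker inhibition and lower numbers for stronger inhibition), compound 3 gives 11300 nM, the second highest of the three numbers. Its nearest neighbour is compound 1, and the step of a 1.9-fold lower number from compound 1 to compound 3 (0.28 log units; within the scatter) lies within the scatter, so the two cannot be ranked against each other. Compound 2 stands furthest from compound 3, with a number that is lower by more than the scatter.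

The step to compound 4 `CC1=C(/C=C/C(=O)/C=C/c2ccccc2F)C(C)(C)CCC1` is fluoro in place of chloro on an aromatic carbon. Neither measured step bears directly on exchanging one halogen for another. For the measured compounds named here, the step of an 11-fold lower number from compound 1 to compound 2 (1.05 log units; beyond the scatter) concerns a nitro group in place of methyl and is large; the step of a 1.9-fold lower number from compound 1 to compound 3 (0.28 log units; within the scatter) is the only other change at the aryl end and stays within the scatter. Going by the values given here, with no precedent for a halogen swap on this ring, a change beyond the scatter in this assay is not expected in either direction.

Compound 4 is therefore expected to give about 13000 nM (range 5000 nM to 35000 nM), a step of a 1.2-fold higher number from compound 3 to compound 4 (0.06 log units; within the scatter) that is estimated to remain within the scatter.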

Compound 4, half-maximal inhibitory concentration: 3400 nM
The estimate for compound 4 lay 3.8-fold (0.58 log units) above the measured number, and the stated range ends above it.
By their numbers in this assay, from the lowest: compounds 2 and 4 (each within the scatter of the next); then compounds 3 and 1 (each within the scatter of the next).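

In this assay, the exchange of chloro for fluoro on an aromatic carbon ortho to a large group proves not to be a neutral swap: a 3.3-fold lower number from compound 3 to compound 4 (0.52 log units; beyond the scatter) is the only halogen exchange shown on this ring, and it lies beyond the scatter. The 2-chlorophenyl group of compound 3 could not be told apart from the 4-methylphenyl group of compound 1, whereas the 2-fluorophenyl group of compound 4 can, with a 6.3-fold lower number from compound 1 to compound 4 (0.80 log units; beyond the scatter) also lying beyond the scatter, so a change beyond the scatter at the aryl end is no longer confined to the nitro group of compound 2. No measurement available here accounts for the difference between the two halogens.

Going by these compounds, whether fluoro would give a comparable number on another carbon of the ring remains open, and so does the question of whether the same holds for a bromo group at this place. It is equally unknown what an amine or a carboxylic acid on this aromatic carbon would give in this assay when set against the two halogens.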